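The source may hold more compounds than are shown below. What is called first, only, known or untested is meant among the compounds shown, and "the series" means these compounds.

Measured in a functional assay on K562 cells (Homo sapiens) for inhibition, read by CCK-8 assay, with a stated time of 72 h; a lower number here means a stronger inhibitor, a higher number a weaker inhibitor:
Compound 1 `CCc1ccc(NS(=O)(=O)c2cccc(CCCCCCNC(=O)/C=C/c3cccnc3)c2)cc1`: 3.89 nM
Compound 2 `O=C(/C=C/c1cccnc1)NCCCCCCc1cccc(S(=O)(=O)Nc2ccc(F)cc2)c1`: 0.93 nM

Of these two, compound 2 holds the lower number, 0.93 nM, and so stands as the stronger inhibitor in this assay. The next compound to consider is compound 3 `O=C(/C=C/c1cccnc1)NCCCCCCc1cccc(S(=O)(=O)Nc2ccc(Oc3ccccc3)cc2)c1`, which is compound 2 with phenoxy in place of fluoro on an aromatic carbon, para to a large group: phenoxy in place of fluoro on an aromatic carbon.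

Going by the values given here, only one measured step bears on this change. It concerns the same aromatic carbon, where fluoro stands in place of ethyl, and a 4.2-fold lower number from compound 1 to compound 2 (0.62 log units; beyond the scatter). That step is modest but beyond the scatter. Among the compounds with values here, it is also the sole evidence, and no measured compound carries phenoxy, so the direction is uncertain. If compound 1, with ethyl, is a fair guide to a group other than fluoro at this place, a modest move towards a higher number is expected on leaving fluoro, of about the size of that step. The expected change is a 3.2-fold higher number from compound 2 to compound 3 (0.51 log units; beyond the scatter). For compound 3 the estimated value is 3 nM, with an expected range of 0.8 nM to 11 nM.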

Compound 3, half-maximal inhibitory concentration: 5.12 nM
Compound 3: the middle estimate sits 1.7-fold (0.23 log units) below what was measured, and the stated range covers the measured number.
By their numbers in this assay, from the lowest: compound 2; then compounds 1 and 3 (each within the scatter of the next).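

With a second group other than fluoro now at this aromatic carbon, para to a large group, the move away from fluoro in this assay again raises the number, here by a step beyond the scatter (a 5.5-fold higher number from compound 2 to compound 3 (0.74 log units; beyond the scatter)), so compound 2 stands as the strongest of the three. Ethyl and phenoxy cannot be told apart at this position, although phenoxy brings an oxygen and a six-membered aromatic ring; their difference lies within the scatter (a 1.3-fold higher number from compound 1 to compound 3 (0.12 log units; within the scatter)). Among the three groups shown, then, fluoro alone stands apart, while the larger phenoxy gives no clear loss beyond that seen with ethyl, and nothing at hand gives a measured reason for this.

Three groups at one position cannot show whether the low number is particular to fluoro or would also appear with a hydrogen, a chlorine or a methoxy group at this carbon. Nor do they show how an amine or a carboxylic acid would behave here, or whether the same order of groups would hold with a different chain length in the shared core.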